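The compounds below may be only part of what the source reports. "The series", "measured", "known", "first", "only" and "open" are said of these compounds alone.

The compounds measured so far, in a functional assay on A-431 cells (Homo sapiens) for antiproliferative activity, read by CCK-8 assay, with a stated time of 48 h; a lower number here means a stronger inhibitor, a higher number a weaker inhibitor:

Compound 1, `COc1ccc(Nc2nc(Nc3cc(C)[nH]n3)cc(N3CCN(C)CC3)n2)cc1OC`, gives 778 nM.
Compound 2, `Cc1cc(Nc2cc(N3CCN(C)CC3)nc(Nc3cccc(F)c3)n2)n[nH]1`, gives 201 nM.

Compound 1 has the highest of the two numbers, that is, it is the weaker inhibitor of the pair; its nearest neighbour is compound 2, which differs from it in one place. Going by the values given here, that single step, a 3.9-fold lower number from compound 1 to compound 2 (0.59 log units; beyond the scatter), is the only measured step that bears on what follows.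

The unmeasured compound 3, `Cc1cc(Nc2cc(N3CCN(C)CC3)nc(Nc3ccc(F)c(F)c3)n2)n[nH]1`, is built from compound 1 by the change (3,4-difluorophenyl in place of 3,4-dimethoxyphenyl on a nitrogen on an aromatic ring). It thus resembles compound 2 closely: both replace the 3,4-dimethoxyphenyl with a fluorine-bearing phenyl on the same nitrogen, and compound 3 simply carries a second fluorine. Among the compounds with values here, since the one comparable step was a clear drop in the number, a drop of roughly that size is expected here as well, though one measurement alone makes the size uncertain.

Compound 3 is therefore estimated at 250 nM, likely between 100 nM and 650 nM. The expected step is a 3.1-fold lower number from compound 1 to compound 3 (0.49 log units; beyond the scatter).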

Compound 3, half-maximal inhibitory concentration: 177 nM
For compound 3 the middle estimate is 1.4-fold (0.15 log units) above the measured one; measured number inside the range.
By their numbers in this assay, from the lowest: compounds 3 and 2 (each within the scatter of the next); then compound 1.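

In this assay, the gain from leaving the 3,4-dimethoxyphenyl behind on this nitrogen is not tied to the 3-fluorophenyl alone, as 3,4-difluorophenyl also gives a step beyond the scatter (a 4.4-fold lower number from compound 1 to compound 3 (0.64 log units; beyond the scatter)). The new one-place comparison, fluoro in place of hydrogen on an aromatic carbon, gives a step within the scatter (a 1.1-fold lower number from compound 2 to compound 3 (0.06 log units; within the scatter)), so the second fluorine brings no difference that this assay can resolve, and compound 2 and compound 3 stand level. No measurement bears on why either fluorine-bearing phenyl differs from the 3,4-dimethoxyphenyl.

Going by these compounds, what stays open is whether the gain comes from losing the two methoxy groups or from gaining fluorine, a question that a plain phenyl or a chlorophenyl on the same nitrogen could help to separate. Also open, on these data alone, is how an amine or a carboxylic acid on this phenyl ring would fare, and how much changes elsewhere on the shared core would matter.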